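A few compounds are considered here, and "the series" means these few. Any claim that something is new, unique, unknown or untested is made for them only; others in the source may bear on it.

Measured in an ADME assay on Vero cells (Chlorocebus sabaeus) for cytotoxicity, read by MTT assay, with a stated time of 72 h; a higher number here means that more compound is tolerated, a lower number that less compound is tolerated:
- compound 1 `O=C(N/N=C/c1ccccc1)c1ccc([N+](=O)[O-])o1`: "not determined" (no result reported)
- compound 2 `Cc1ccc(/C=N/NC(=O)c2ccc([N+](=O)[O-])o2)cc1`: > 228000 nM
- compound 3 `C/C(=N\NC(=O)c1ccc([N+](=O)[O-])o1)c1ccccc1`: > 228000 nM

Compound 3 gives > 228000 nM, which is a limit and not a number. Its place in the series is the limit of > 228000 nM in this assay, at which 2 of the 3 values shown sit. Compound 4 `C/C(=N\NC(=O)c1ccc([N+](=O)[O-])o1)c1ccc(C)cc1` differs from compound 3 by methyl in place of hydrogen on an aromatic carbon, para to a large group: methyl in place of hydrogen on an aromatic carbon. Among the measured compounds shown here, no measured step in this assay shows what this change does. Compound 2, which also carries 4-methylphenyl, gives > 228000 nM, again a limit. No step beyond the scatter is therefore expected, and another limit is likely. The expected change is a number no higher from compound 3 to compound 4 (the limit leaves the size open). For compound 4 the estimated value is 228000 nM, with an expected range of 110000 nM to 450000 nM.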

Compound 4, half-maximal cytotoxic concentration: > 217000 nM
Compound 4 was reported as a limit; the forecaster's own chance of this, stated with the estimate: 75%; the middle value is on the limit's open side.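

Among the compounds shown here, compound 3 and compound 4 are both reported only as limits in this assay, and no step between them can be read. The compounds shown leave open what methyl in place of hydrogen on an aromatic carbon does in this assay.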